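A few compounds are considered here, and "the series" means these few. Any claim that something is new, unique, unknown or untested is made for them only; others in the source may bear on it.

Measured in a functional assay on ACHN cells (Homo sapiens); on this read-out lower numbers stand for stronger inhibition of growth and higher numbers for weaker inhibition of growth:
- compound 1 `N#Cc1ccc(/C=C/S(=O)(=O)Cc2ccc(Nc3ncnc4ccccc34)cc2)cc1`: > 100000 nM
- compound 2 `O=S(=O)(/C=C/c1ccc(Cl)c(Cl)c1)Cc1ccc(Nc2ncnc3ccccc23)cc1`: 28000 nM
- compound 3 `O=S(=O)(/C=C/c1ccc(Br)cc1)Cc1ccc(Nc2ncnc3ccccc23)cc1`: 200 nM

The entry for compound 1 is a limit of the assay, not a number.

Compound 3 has the lowest number of the three, with compound 2 its nearest neighbour. Next is compound 4 `O=S(=O)(/C=C/c1ccc(Cl)cc1)Cc1ccc(Nc2ncnc3ccccc23)cc1`, with chloro in place of bromo on an aromatic carbon, para to a large group (chloro in place of bromo on an aromatic carbon). Two measured steps change this same end of the molecule: a 140-fold lower number from compound 2 to compound 3 (2.15 log units; beyond the scatter) and an at least 500-fold lower number from compound 1 to compound 3 (2.69 log units; beyond the scatter). Both are large, so small changes here can matter in this assay, though neither is this exact exchange. A modest rise is expected, a 3.0-fold higher number from compound 3 to compound 4 (0.48 log units; beyond the scatter). Compound 4 is estimated at 600 nM, with an expected range of 100 nM to 10000 nM.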

Compound 4, concentration for 50% growth inhibition: > 100000 nM
Compound 4 gave a limit, no number; the forecaster's own chance of this, stated with the estimate: 3%; at least 160-fold (2.22 log units) between middle value and limit.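

In this assay, one halogen exchange on an aromatic carbon, para to a large group, gives an at least 500-fold higher number from compound 3 to compound 4 (2.69 log units; beyond the scatter), so bromo and chloro are not interchangeable at this position. Hydrogen in place of chloro on the same ring gives an at least 3.5-fold higher number from compound 2 to compound 4 (0.55 log units; beyond the scatter), so the 3,4-dichlorophenyl of compound 2 retains a measurable value where the 4-chlorophenyl of compound 4 reaches only a limit. The step between compound 1 and compound 4 cannot be read, since both entries are limits: the limit of > 100000 nM in this assay, at which 2 of the 4 values shown sit.

Going by these compounds, whether iodo, methyl or an amine at this position would land near compound 3 or at the limit remains open.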